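Swapping Halogens on the Aryl Ring Attached to a Ring Amine

The source may hold more compounds than are shown below. What is called first, only, known or untested is meant among the compounds shown, and "the series" means these compounds.

Among the measured compounds shown here, compound 1 `Nc1scc(CN2CCN(c3cccc(Cl)c3Cl)CC2)c1C(=O)c1ccc(Cl)cc1` stands at the smaller of the two numbers so far, a gap that lies within the usual scatter: in an assay on CHO cells for displacement of a labelled ligand from adenosine receptor A3 (Homo sapiens), read by scintillation counting, with a stated time of 120 min, tested at 10 uM (on this read-out lower numbers stand for less inhibition and higher numbers for more inhibition at the one concentration tested (going by the name of the read-out)), compound 1 gives 0%. Compound 2 `Nc1scc(CN2CCN(c3cc(Cl)cc(Cl)c3)CC2)c1C(=O)c1ccc(Cl)cc1` gives 1% in this assay, and the step of a number 1 percentage points higher from compound 1 to compound 2 (within the scatter) shows that exchanging one pair of chlorines for another left the read-out flat. Compound 3 `Nc1scc(CN2CCN(c3ccc(F)cc3Cl)CC2)c1C(=O)c1ccc(Cl)cc1` differs from compound 1 by 2-chloro-4-fluorophenyl in place of 2,3-dichlorophenyl on an amine nitrogen in a ring. For the measured compounds named here, only that single flat step bears on this change, so the estimated step is a number 2 percentage points higher from compound 1 to compound 3 (within the scatter), with nothing beyond the scatter expected. Compound 3 is therefore expected to give 2% in this assay, within a range from -8% to 12%.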

Compound 3, a percentage reported as inhibition, at one concentration (the size of the read-out at that concentration, not a potency): 0%
Compound 3: the middle estimate sits 2 percentage points above what was measured, within the range that was stated.
By their numbers in this assay, from the lowest: compounds 1, 3 and 2 (each within the scatter of the next).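

A fluorine now enters the aryl group on the ring amine: 2-chloro-4-fluorophenyl gives no change at the digits printed from compound 1 to compound 3 (within the scatter) and a number 1 percentage points lower from compound 2 to compound 3 (within the scatter) in this assay so three halogen patterns at this position now read alike. The flat result thus extends beyond moving chlorines to changing one halogen for another. Nothing measured here explains this flatness.

From the compounds shown here alone, all three compounds carry chlorine on this phenyl ring, so the effect of a different group there stays open. A methoxy group or an amine on that ring could show whether this position can move the read-out at all.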